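The source may hold more compounds than are shown below. What is called first, only, known or untested is meant among the compounds shown, and "the series" means these compounds.

Three compounds sharing one core were examined in a functional assay on the whole organism (aorta) with Rattus norvegicus as the target; a lower number here means a smaller maximal response, a higher number a larger maximal response. Compound 1 `CCNS(=O)(=O)c1ccc2c(c1)C(n1ccccc1=O)=CC(C)(C)O2` gives 72.4%. Compound 2 `CC(C)NS(=O)(=O)c1ccc2c(c1)C(n1ccccc1=O)=CC(C)(C)O2` gives 76.9%. Compound 3 `CC1(C)C=C(n2ccccc2=O)c2cc(S(=O)(=O)Nc3ccc([N+](=O)[O-])cc3)ccc2O1` gives 82.2%. On these numbers compound 3 holds the highest of the three values, yet the gaps to it are a number 5.3 percentage points higher from compound 2 to compound 3 (within the scatter) and a number 9.8 percentage points higher from compound 1 to compound 3 (within the scatter), so no real separation between the three is shown; the remaining comparison, a number 4.5 percentage points higher from compound 1 to compound 2 (within the scatter), is also within the scatter.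

Compound 4 `CC1(C)C=C(n2ccccc2=O)c2cc(S(=O)(=O)NC(=O)Nc3ccccc3)ccc2O1` differs from compound 3 in one place: phenylcarbamoyl in place of 4-nitrophenyl on a sulfonamide nitrogen. Going by the values given here, the steps that bear on this change are those that already exchanged the group on the sulfonamide nitrogen, from ethyl or isopropyl to 4-nitrophenyl, and both stayed within the scatter. Among the compounds with values here, since none of the measured exchanges at this nitrogen moved the maximal response beyond the scatter, compound 4 is expected to show no step beyond it either, a number 3.2 percentage points lower from compound 3 to compound 4 (within the scatter). Compound 4 is therefore estimated at 79%, with a range from 64% to 94%.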

Compound 4, largest response reached (Emax), in percent of the reference or control that the assay uses: 90.8%
For compound 4 the middle estimate is 11.8 percentage points below the measured one; measured number inside the range.
By their numbers in this assay, from the lowest: compounds 1, 2, 3 and 4 (each within the scatter of the next, the first and the last beyond it).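

In this assay, going by these compounds alone, the sulfonamide nitrogen now gives steps beyond the scatter for the first time, though modest ones: phenylcarbamoyl in place of isopropyl gives a number 13.9 percentage points higher from compound 2 to compound 4 (beyond the scatter) and phenylcarbamoyl in place of ethyl gives a number 18.4 percentage points higher from compound 1 to compound 4 (beyond the scatter). Phenylcarbamoyl in place of 4-nitrophenyl gives only a number 8.6 percentage points higher from compound 3 to compound 4 (within the scatter), so these two groups are not separated, and only phenylcarbamoyl stands apart from the ethyl and isopropyl groups. No available evidence accounts for this result.

From the compounds shown here alone, it remains open whether the carbonyl or the terminal phenyl ring of phenylcarbamoyl goes with the higher maximal response, a question that acetyl or methylcarbamoyl on the sulfonamide nitrogen would address. Also open, going by these compounds, is how a 4-nitrophenylcarbamoyl group or a benzoyl group at this nitrogen would compare.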